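A Longer Chain on the Saturated Ring of Compound 3

This account rests on a few compounds, and the source may have more. Where it says the series, first, only, none or still open, it means among the compounds named here.

Of the compounds shown here, three built on one shared core have been tested in an assay on cells for agonist activity at Toll-like receptor 2 (Homo sapiens), with a stated time of 24 h; a higher number here means that more compound is needed for the effect, a lower number that less compound is needed. Compound 1 `CCCOC(=O)c1c(NC(=O)N2CCN(C)CC2)sc2c1CCC2` gives 14200 nM. Compound 2 `CN1CCN(C(=O)Nc2sc3c(c2C(=O)O)CCC3)CC1` is reported as "not active" (no number reported), without a number. Compound 3 `COC(=O)c1c(NC(=O)N2CCN(C)CC2)sc2c1CCC(C)C2` gives 11800 nM. Among the measured compounds shown here, compound 3 thus holds one of only two numbers in this assay, and its nearest neighbour, compound 1, lies within the scatter of it, so the two cannot be told apart on these data.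

Compound 4 `CCCCCC1CCc2c(sc(NC(=O)N3CCN(C)CC3)c2C(=O)OC)C1` has not yet been measured. It differs from compound 3 in one place: butyl in place of hydrogen on a saturated chain carbon bound to a saturated ring carbon; cut one bond further out, the same difference reads methyl to pentyl. For the measured compounds named here, no pair of measured compounds shows a step of this kind, so there is nothing to copy from. Compound 1 and compound 3 differ in more than one place and still give numbers within the scatter of each other, which hints at a flat response to small changes. The expected step is therefore a 1.2-fold lower number from compound 3 to compound 4 (0.07 log units; within the scatter), small and without a clear direction beyond the scatter. Compound 4 is expected to give about 10000 nM, within a range from 3000 nM to 40000 nM.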

Compound 4, half-maximal effective concentration: "not active" (no number reported)
Nothing numeric was reported for compound 4; the estimate stays without a comparison.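

In this assay, among the compounds shown here, compound 4 is reported as "not active" (no number reported) and so no step from compound 3 to compound 4 can be read. No evidence on this result is available. The compounds shown leave open how chains between methyl and pentyl would behave at this place.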